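The source may report more compounds than this note shows. Statements on the series, on what has been measured and on what is new or still open speak of the compounds shown alone.

Measured compounds:

- compound 1 `CC(C)C(=O)NC(C(=O)N1CCC(c2ccc(Cl)cc2)CC1)C(C)C`: 388 nM
- compound 2 `O=C(N[C@@H](C(=O)N1CCC(c2ccc(Cl)cc2)CC1)C1CCCCC1)c1ccccc1`: 121 nM
- compound 3 `CC(C)C(NC(=O)c1ccccc1)C(=O)N1CCN(c2ccc(Cl)cc2)CC1`: 525 nM

All three were tested in an assay on THP-1 cells for displacement of a labelled ligand from C-C chemokine receptor type 1 (Homo sapiens); a lower number here means a stronger inhibitor, a higher number a weaker inhibitor. Among these three numbers compound 1 stands second highest. Its nearest neighbour is compound 3, whose value lies within the usual scatter of compound 1, so the two cannot be told apart. Compound 2 stands further away, with a lower number than compound 1 that lies beyond the scatter, and compound 2 is the only one of the three that carries an aromatic ring on the amide carbonyl.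

Compound 4 `CC(C)C(NC(=O)c1ccc2ccccc2c1)C(=O)N1CCC(c2ccc(Cl)cc2)CC1` has not yet been measured. It is built from compound 1 with one change: naphthalen-2-yl in place of isopropyl on a carbonyl carbon

Going by the values given here, no measured pair differs in exactly this way, so the size of the step has to be guessed. Compound 2, with an aromatic group on the same carbonyl, gives 121 nM, which hints that this kind of change can lower the number. The step from compound 1 to compound 4 is therefore expected to be a 2.6-fold lower number from compound 1 to compound 4 (0.41 log units; beyond the scatter), a drop somewhat beyond the scatter, though a flat result cannot be excluded. For compound 4 the expected value is 150 nM, with a likely range from 40 nM to 600 nM.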

Compound 4, half-maximal inhibitory concentration: 80 nM
The estimate for compound 4 lay 1.9-fold (0.27 log units) above the measured number; the range from low to high includes it.
By their numbers in this assay, from the lowest: compounds 4 and 2 (each within the scatter of the next); then compounds 1 and 3 (each within the scatter of the next).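

In this assay, going by these compounds alone, replacing isopropyl with naphthalen-2-yl on the carbonyl carbon gives a 4.9-fold lower number from compound 1 to compound 4 (0.69 log units; beyond the scatter) and is the first change in this set made at a single place. It shows that the group at this position can move the number beyond the usual scatter while the rest of compound 1 stays the same. The entering group has 10 heavy atoms of carbon against 3 for isopropyl and adds no hydrogen-bond donors or acceptors, but no measurement here bears on what lies behind the drop.

Going by these compounds, it remains open whether both aromatic rings are needed, which a pyridine ring or a longer chain such as n-hexyl on the same carbonyl carbon could help test. On these data alone, it is also open whether the same change would lower the number on the core of compound 3.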